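This account rests on a few compounds, and the source may have more. Where it says the series, first, only, none or still open, it means among the compounds named here.

Compound 1 `COc1cc(-c2nnc(SCC(=O)Nc3ccccc3C)n2N)cc(OC)c1OC`: in a functional assay on HepG2 cells (Homo sapiens) for antiproliferative activity, read by MTT assay, with a stated time of 48 h (on this read-out lower numbers stand for stronger inhibition and higher numbers for weaker inhibition), compound 1 reaches only a limit, > 100000 nM.
Compound 2 `COc1cc(-c2nnc(SCC(=O)Nc3ccccc3F)n2N)cc(OC)c1OC`: in this assay compound 2 gives 18700 nM.

Going by the values given here, compound 2 holds the only actual number in this assay; the other value recorded there is a limit (the limit of > 100000 nM in this assay, at which 1 of the 2 values shown sits), not a number. Compound 3 `COc1ccc(CNC(=O)CSc2nnc(-c3cc(OC)c(OC)c(OC)c3)n2N)cc1OC` differs from compound 2 by 3,4-dimethoxybenzyl in place of 2-fluorophenyl on an amide-type nitrogen. Among the compounds with values here, the single measured step, an at least 5.3-fold lower number from compound 1 to compound 2 (0.72 log units; beyond the scatter), exchanges one small substituent on the aromatic ring attached to the amide nitrogen, whereas the move to compound 3 replaces that whole 2-fluorophenyl ring with the 3,4-dimethoxybenzyl group. The measured step is therefore of a different kind and gives no direct guide to the size or direction of the change in this assay. Within the data shown here, with only one number to rest on, the expected step for compound 3 is a 1.6-fold higher number from compound 2 to compound 3 (0.21 log units; within the scatter), carrying wide uncertainty. Compound 3 is estimated at 30000 nM, in the range 8000 nM to 100000 nM.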

Compound 3, half-maximal inhibitory concentration: > 100000 nM
Compound 3: no number, only a limit (the forecaster's own chance of this, stated with the estimate: 35%); at least 3.3-fold (0.52 log units) between middle value and limit.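

On the amide-type nitrogen, 3,4-dimethoxybenzyl in place of 2-fluorophenyl gives an at least 5.3-fold higher number from compound 2 to compound 3 (0.72 log units; beyond the scatter), so the activity seen with compound 2 in this assay does not carry over to this larger group. Compound 3 reaches only a limit, > 100000 nM, which is not a number, so the true size of the loss cannot be told. The step between compound 1 and compound 3 cannot be read, since both ends are limits, and compound 2 alone stands clear of that limit: the limit of > 100000 nM in this assay, at which 2 of the 3 values shown sit.

Going by these compounds, it remains open which part of the exchange counts, the benzyl group itself or its two methoxy groups; an unsubstituted benzyl group on the same nitrogen would separate the two. Also open, on these data alone, is whether a chloro group or an amine on the phenyl ring would give an actual number in this assay.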